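This account rests on a few compounds, and the source may have more. Where it says the series, first, only, none or still open, it means among the compounds named here.

Measured so far in a functional assay on MV4-11 cells (Homo sapiens) for antiproliferative activity, read by CellTiter-Glo, with a stated time of 72 h; on this read-out lower numbers stand for stronger inhibition of growth and higher numbers for weaker inhibition of growth:

- compound 1 `CC(=O)N[C@H]1CC[C@H](Nc2cc(-c3csc(NCC4CCOCC4)n3)c(Cl)cn2)CC1`: 3600 nM
- compound 2 `COCCCN[C@H]1CC[C@H](Nc2cc(-c3csc(NCC4CCOCC4)n3)c(Cl)cn2)CC1`: 1090 nM
- compound 3 `CCOCCN[C@H]1CC[C@H](Nc2cc(-c3csc(NCC4CCOCC4)n3)c(Cl)cn2)CC1`: 497 nM

All three share one core and differ only in the group on an amine nitrogen. Among them, compound 3 gives the lowest number, 497 nM, and so the strongest inhibition of growth in this assay.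

The next compound, compound 4 `COC[C@H](C)N[C@H]1CC[C@H](Nc2cc(-c3csc(NCC4CCOCC4)n3)c(Cl)cn2)CC1`, carries 1-(methoxymethyl)ethyl in place of 2-ethoxyethyl on an amine nitrogen. The two compounds have the same atoms, joined differently.

The closest guide is the swap between the two ether chains, a 2.2-fold lower number from compound 2 to compound 3 (0.34 log units; beyond the scatter). Rearranging a chain of this kind has therefore moved the number only a little. Replacing acetyl had larger effects, a 3.3-fold lower number from compound 1 to compound 2 (0.52 log units; beyond the scatter) and a 7.2-fold lower number from compound 1 to compound 3 (0.86 log units; beyond the scatter), but that is a different kind of change and bears on compound 4 only loosely. Among the measured compounds shown here, no measured compound carries 1-(methoxymethyl)ethyl, so its effect remains untested and either direction is possible.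

No step beyond the usual scatter is expected, and the estimated change is a 1.0-fold higher number from compound 3 to compound 4 (0.00 log units; within the scatter). The estimated value for compound 4 is 500 nM, with an expected range from 170 nM to 1500 nM.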

Compound 4, concentration for 50% growth inhibition: 440 nM
The estimate for compound 4 lay 1.1-fold (0.06 log units) above the measured number, within the range that was stated.
By their numbers in this assay, from the lowest: compounds 4 and 3 (each within the scatter of the next); then compound 2; then compound 1.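

In this assay, replacing 2-ethoxyethyl with 1-(methoxymethyl)ethyl on the amine nitrogen gives a 1.1-fold lower number from compound 3 to compound 4 (0.05 log units; within the scatter), so these two arrangements of the same atoms cannot be told apart here, even though the second adds a defined stereocentre. Not every ether chain matches them, however: 3-methoxypropyl is the exception, with a 2.5-fold lower number from compound 2 to compound 4 (0.39 log units; beyond the scatter), and the gain over the acetyl group reaches an 8.2-fold lower number from compound 1 to compound 4 (0.91 log units; beyond the scatter), which places compound 4 alongside compound 3 at the low end of this small set. Nothing available explains why these two chains give matching numbers or why 3-methoxypropyl differs from them.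

The compounds shown leave open whether the mirror-image form of 1-(methoxymethyl)ethyl would match compound 4, which would show whether the arrangement at the new stereocentre matters in this assay. They also leave open how this amine nitrogen would respond to groups of a different kind, such as a chain ending in a hydroxyl group, a chain ending in a carboxylic acid, or a longer ether chain.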